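Amide nitrogen substituent: isopropyl to cyclopropyl

The source may hold more compounds than are shown below. What is called first, only, known or untested is meant among the compounds shown, and "the series" means these compounds.

Compound 3 `Cc1cc(C(=O)NC(C)C)nn1Cc1cc(Cl)cc2cc(-c3ccccc3)oc12` gives 10 nM in an assay on CHO-K1 cells for displacement of a labelled ligand from prostaglandin E2 receptor EP1 subtype (Homo sapiens), read by scintillation counting, with a stated time of 45 min (on this read-out higher numbers stand for weaker inhibition and lower numbers for stronger inhibition), the lowest of the two numbers in hand. Compound 1 `CCCc1cc2cc(Cl)cc(Cn3nc(C(=O)O)cc3C)c2o1`, which carries a free acid in place of the amide and a propyl group in place of the phenyl group on its core, gives 25.1 nM in this assay, a higher number that lies beyond the scatter of the method. Compound 2 `Cc1cc(C(=O)O)nn1Cc1cc(Cl)cn2nc(C(C)C)cc12`, built on a different core, reaches only a limit of the assay and no number: in this assay compound 2 gives > 1000 nM, which is the limit of > 1000 nM in this assay, at which 1 of the 3 values shown sits.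

Compound 4 `Cc1cc(C(=O)NC2CC2)nn1Cc1cc(Cl)cc2cc(-c3ccccc3)oc12` has not been measured. It differs from compound 3 by cyclopropyl in place of isopropyl on an amide-type nitrogen, with the rest of compound 3 kept. Among the measured compounds shown here, no pair of measured compounds covers a change of this kind, so the expectation rests on the size and character of the exchange alone: two groups of the same count of carbon atoms, neither with donors or acceptors, at the same position. The step from compound 3 to compound 4 is estimated at no change at the digits printed from compound 3 to compound 4 (within the scatter), that is, none beyond the scatter in either direction. Compound 4 is accordingly expected to give 10 nM in this assay, with a range from 4 nM to 30 nM.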

Compound 4, half-maximal inhibitory concentration: 5.01 nM
The estimate for compound 4 lay 2.0-fold (0.30 log units) above the measured number, and the stated range covers the measured number.
By their numbers in this assay, from the lowest: compounds 4 and 3 (each within the scatter of the next); then compound 1. At a limit, above all of these: compound 2.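

In this assay, replacing isopropyl with cyclopropyl on the amide-type nitrogen gives a 2.0-fold lower number from compound 3 to compound 4 (0.30 log units; within the scatter) and the two substituents cannot be told apart at this position. The entering group adds one three-membered non-aromatic ring of carbon only and keeps the same count of heavy atoms, so closing the ring here costs nothing that this read-out can detect. Among the compounds shown here, the earlier compounds offered no pair differing in one place, which makes this the first reading of a single change, and it holds only for this one pair on the core shared by compound 3 and compound 4.

Open, on these data alone, is whether the same position accepts a longer chain such as n-butyl, a tert-butyl group, or a substituent carrying a hydroxyl group or an amine, and whether the amide differs from a carboxylic acid on this core, a question compound 1 cannot settle with its two differences from compound 3. Nothing shown gives a reason for the step between these two amides.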